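A few compounds are considered here, and "the series" means these few. Any claim that something is new, unique, unknown or untested is made for them only; others in the source may bear on it.

Of the compounds shown here, three from this series have been tested so far. Compound 1 `Cc1cccc(NC(=O)c2c(O)c3cccnc3n(-c3ccccc3)c2=O)c1` gives 4.5% in a functional assay on the whole organism for inhibition, with Rattus norvegicus as the target, read by cytopathic effect and paw edema, at a dose of 100 mg/kg by the oral route; a lower number here means less inhibition, a higher number more inhibition at the dose given (going by the name of the read-out). Compound 2 `O=C(Nc1ccncc1)c1c(O)c2cccnc2n(-c2ccccc2)c1=O` gives 24.3% in this assay, and compound 3 `O=C(NCc1cccnc1)c1c(O)c2cccnc2n(-c2ccccc2)c1=O` gives 14.7%. On these numbers compound 3 stands second highest of the three: its step to compound 2 lies within the scatter, while the step of a number 10.2 percentage points higher from compound 1 to compound 3 (beyond the scatter) lies beyond it, as does the step of a number 19.8 percentage points higher from compound 1 to compound 2 (beyond the scatter).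

The piece now turns to compound 4 `O=C(Nc1ccc(Cl)nc1)c1c(O)c2cccnc2n(-c2ccccc2)c1=O`, which is not yet measured. Its difference from compound 3 is 6-chloropyridin-3-yl in place of (pyridin-3-yl)methyl on an amide-type nitrogen. Two measured steps speak to this change. The step of a number 9.6 percentage points lower from compound 2 to compound 3 (within the scatter) shows that exchanging a pyridinyl ring for a methylene-linked pyridinyl ring on the amide-type nitrogen moved the number no further than the scatter. The step of a number 19.8 percentage points higher from compound 1 to compound 2 (beyond the scatter) shows that a ring change on the same nitrogen can move the number by a modest amount. Among the compounds with values here, no measured step covers the entry of a chlorine on the pyridinyl ring, so that part of the change is unsupported by the data. The account therefore expects a step of a number 5.3 percentage points higher from compound 3 to compound 4 (within the scatter) that stays within the scatter, with the number likely to fall near those of compound 2 and compound 3. The estimate for compound 4 in this assay is 20%, with a range from 5% to 38%.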

Compound 4, a percentage reported as inhibition, in the whole organism at one dose (the size of the read-out at that dose, not a potency): -4%
Compound 4: the middle estimate sits 24 percentage points above what was measured; measured number outside the range, below it.
By their numbers in this assay, from the lowest: compounds 4 and 1 (each within the scatter of the next); then compounds 3 and 2 (each within the scatter of the next).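

Compound 4 shows that a pyridinyl ring on the amide-type nitrogen does not by itself hold the number in this assay above that of the 3-methylphenyl amide, which both earlier pyridinyl compounds had suggested. Putting 6-chloropyridin-3-yl on this nitrogen gives a number 18.7 percentage points lower from compound 3 to compound 4 (beyond the scatter) and a number 28.3 percentage points lower from compound 2 to compound 4 (beyond the scatter), so this change moves the number beyond the scatter, unlike the exchange between the two earlier pyridinyl groups. The step of a number 8.5 percentage points lower from compound 1 to compound 4 (within the scatter) means that compound 4 cannot be told apart from the 3-methylphenyl amide, and nothing measured on these compounds explains the result.

Each step to compound 4 alters more than one feature of the group on the nitrogen, so the compounds shown cannot separate the entry of the chlorine from the change in how the pyridinyl ring is attached. On these data alone, it also stays open how plain pyridin-3-yl on the amide-type nitrogen would read in this assay, and how the number would respond to a methoxy group or an amine in place of the chlorine.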